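Propylamino for methylamino on the nitrile-bearing core

This account rests on a few compounds, and the source may have more. Where it says the series, first, only, none or still open, it means among the compounds named here.

For the measured compounds named here, compound 1, `CCCNc1nc(NCc2ccc(C(=O)Nc3ccc(F)cc3)cc2)c2cc(C)ccc2n1`, and compound 2, `CNc1nc2ccccc2c(NCc2ccc(NC(=O)c3ccc(F)cc3)cc2)c1C#N`, are the two measured members of this set. In a functional assay on HCT-116 cells (Homo sapiens) for inhibition, read by luminescence and resazurin assay, with a stated time of 3 days (on this read-out lower numbers stand for stronger inhibition and higher numbers for weaker inhibition), compound 1 gives 1200 nM. Compound 2 reaches only the limit of > 20000 nM in this assay, so for compound 2 there is no number, only a limit, and this is noted as the limit of > 20000 nM in this assay, at which 1 of the 2 values shown sits. Going by the values given here, compound 1 and compound 2 differ in more than one place, so their two values show only that the one carries a number and the other a limit.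

Compound 3, `CCCNc1nc2ccccc2c(NCc2ccc(NC(=O)c3ccc(F)cc3)cc2)c1C#N`, is the next member. It differs from compound 2 by ethyl in place of hydrogen on a saturated chain carbon bound to a nitrogen on an aromatic ring.

Among the compounds with values here, no step between measured compounds is recorded here, so the size of the change from compound 2 to compound 3 in this assay is open. The expectation is a modest gain for compound 3, an at least 1.3-fold lower number from compound 2 to compound 3 (0.12 log units; that floor lies within the scatter), though a reading that again stops at the limit is held to be about as likely as a number. Compound 3 is therefore estimated at 15000 nM, with a range from 5000 nM to 40000 nM.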

Compound 3, half-maximal inhibitory concentration: > 20000 nM
Compound 3: a limit, no number; the forecaster's own chance of this, stated with the estimate: 50%; at least 1.3-fold (0.12 log units) between middle value and limit.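

Compound 2 and compound 3 both stop at a limit rather than a number in this assay, so no step can be read for propylamino in place of methylamino: the limit of > 20000 nM in this assay, at which 2 of the 3 values shown sit. The compounds shown leave open how methylamino and propylamino compare on the shared core, and what number either compound would carry in this assay.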